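The compounds below may be only part of what the source reports. "The series", "measured", "known", "first", "only" and "open" are said of these compounds alone.

Compound 1 `CCCCc1ccc2c(c1)C(=O)C(=O)N2`: > 10000 nM (a limit)
Compound 2 `Cc1ccc(-c2ccc3c(c2)C(=O)C(=O)N3)cc1`: > 10000 nM (a limit)
Compound 3 `CCN1C(=O)C(=O)c2cc(-c3ccc(OC)cc3)ccc21`: 2200 nM

All three were tested in a functional assay on K562 cells (Homo sapiens) for antiproliferative activity, read by MTT assay, with a stated time of 48 h; on this read-out lower numbers stand for stronger inhibition and higher numbers for weaker inhibition. Compound 1 reports only a limit, > 10000 nM. Compound 2 likewise reports only a limit, > 10000 nM. Among the measured compounds shown here, compound 3, at 2200 nM, is the only one with an actual number.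

Compound 4 `COc1ccc(-c2ccc3c(c2)C(=O)C(=O)N3Cc2ccc(F)cc2)cc1` keeps the core of compound 3 and changes one group: 4-fluorophenyl in place of methyl on a saturated chain carbon bound to an amide-type nitrogen in a ring. Here, 4-fluorophenyl stands in place of methyl on a saturated chain carbon bound to an amide-type nitrogen in a ring, so ethyl becomes 4-fluorobenzyl. For the measured compounds named here, no measured pair shows this change, so the expectation is tentative: a clear move towards stronger inhibition in this assay, starting from compound 3 at 2200 nM. The expected step is a 6.3-fold lower number from compound 3 to compound 4 (0.80 log units; beyond the scatter). The estimate for compound 4 is 350 nM, with an expected range of 60 nM to 1800 nM.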

Compound 4, half-maximal inhibitory concentration: 560 nM
The estimate for compound 4 lay 1.6-fold (0.20 log units) below the measured number; low and high end bracket the measured number.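

In this assay, among the compounds shown here, replacing ethyl with 4-fluorobenzyl gives a 3.9-fold lower number from compound 3 to compound 4 (0.59 log units; beyond the scatter), the first step that can be read at this place. It shows that a saturated chain carbon bound to an amide-type nitrogen in a ring can carry a much larger group, here an added aromatic ring, while the number still falls. The earlier compounds could not show this, because they form no measured pair and two values are limits: the limit of > 10000 nM in this assay, at which 2 of the 4 values shown sit.

The compounds shown leave open whether the fluorine or the aromatic ring itself accounts for this step. Plain benzyl would separate the two, and a chain ending in an amine would test a quite different group at this place.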